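Thiazolyl to cyanophenyl swap on the piperidine of compound 1

The source may hold more compounds than are shown below. What is called first, only, known or untested is meant among the compounds shown, and "the series" means these compounds.

Measured so far:
- compound 1, `Cc1cccc(NC(=O)CN2CCC(c3nccs3)CC2)c1`: 1 nM
- compound 2, `O=C(CN1CCC(c2cccc[n+]2[O-])CC1)Nc1cccc(F)c1`: 160 nM

In a functional assay on HEK293 cells for agonist activity at D(4) dopamine receptor (Homo sapiens), read by FLIPR (on this read-out lower numbers stand for an effect already at smaller amounts and higher numbers for an effect only at larger amounts of compound), compound 1 gives 1 nM and has the lowest number of the two measured compounds. Within the data shown here, compound 2 carries a different pair of groups and gives 160 nM in this assay, a gap beyond the scatter; no single-point step links the two, so their values are simply compared side by side.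

Compound 3, `Cc1cccc(NC(=O)CN2CCC(c3ccccc3C#N)CC2)c1`, is not yet measured. Compared with compound 1 the change is 2-cyanophenyl in place of 1,3-thiazol-2-yl on a saturated ring carbon. The amide side stays as in compound 1. Among the measured compounds shown here, with no measured step of this kind, the expectation rests on compound 1 alone: a modest loss, a 5.0-fold higher number from compound 1 to compound 3 (0.70 log units; beyond the scatter), is estimated, staying within the low range set by compound 1 at 1 nM rather than reaching compound 2. Compound 3 is expected at about 5 nM in this assay, within 1 nM to 30 nM.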

Compound 3, half-maximal effective concentration: 8 nM
For compound 3 the middle estimate is 1.6-fold (0.20 log units) below the measured one; the range from low to high includes it.
By their numbers in this assay, from the lowest: compound 1; then compound 3; then compound 2.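

The first step measured at this position, the saturated ring carbon three ring bonds from the ring nitrogen, is 2-cyanophenyl in place of 1,3-thiazol-2-yl, and in this assay it gives an 8.0-fold higher number from compound 1 to compound 3 (0.90 log units; beyond the scatter) with the amide side unchanged. The step is beyond the scatter but modest, so a six-membered aromatic ring of carbon only bearing a nitrile can replace the five-membered aromatic ring with 2 hetero atoms and keep agonist activity in the low range of this series. Nothing available accounts for the size of this step.

The compounds shown do not separate the contribution of the ring swap from that of the nitrile, which an unsubstituted phenyl would address. On these data alone, whether a methoxy group or a chlorine in place of the nitrile, or a different amide side, would keep this activity also remains open.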